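Hydroxy for methyl on the amide side chain

This account rests on a few compounds, and the source may have more. Where it says the series, first, only, none or still open, it means among the compounds named here.

Measured so far:
compound 1 `CCC(=O)Nc1cc(Oc2ccc(Nc3nccc4[nH]cc(-c5ccc(F)cc5)c(=O)c34)cc2F)ccn1`: 68.7%
compound 2 `CC(C)(C)C(=O)Nc1cc(Oc2ccc(Nc3nccc4[nH]cc(-c5ccc(F)cc5)c(=O)c34)cc2F)ccn1`: -45.8%

In a functional assay on HT-29 cells (Homo sapiens) for antiproliferative activity, read by MTT assay, with a stated time of 72 h, tested at 10 uM (on this read-out higher numbers stand for more inhibition at the one concentration tested (going by the name of the read-out) and lower numbers for less inhibition), compound 1 gives 68.7% and compound 2 gives -45.8%, the lower of the two numbers. For the measured compounds named here, the one measured step, a number 114.5 percentage points lower from compound 1 to compound 2 (beyond the scatter), concerns the alkyl group on the carbonyl carbon and is large.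

Compound 3 `CC(C)(O)C(=O)Nc1cc(Oc2ccc(Nc3nccc4[nH]cc(-c5ccc(F)cc5)c(=O)c34)cc2F)ccn1` differs from compound 2 by hydroxy in place of methyl on a saturated chain carbon bound to a carbonyl carbon and two saturated chain carbons. Going by the values given here, no measured step covers this exchange; the step to compound 2 shows only that the branched group lowered the read-out. For compound 3 a modest upward move is expected, a number 45.8 percentage points higher from compound 2 to compound 3 (beyond the scatter), with wide uncertainty. Compound 3 is thus estimated at 0%, range -45% to 50%.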

Compound 3, a percentage reported as inhibition, at one concentration (the size of the read-out at that concentration, not a potency): -2.9%
The estimate for compound 3 lay 2.9 percentage points above the measured number; measured number inside the range.
By their numbers in this assay, from the lowest: compound 2; then compound 3; then compound 1.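

In this assay, hydroxy in place of methyl on this saturated chain carbon recovers part of the read-out lost with the tert-butyl group (a number 42.9 percentage points higher from compound 2 to compound 3 (beyond the scatter)). The 1-hydroxy-1-methylethyl group still does not match ethyl on the carbonyl carbon (a number 71.6 percentage points lower from compound 1 to compound 3 (beyond the scatter)). Nothing at hand gives a reason for either step.

Open, going by these compounds, is how an amine on the same saturated chain carbon would read. Also open, on these data alone, is whether a longer unbranched chain on the carbonyl carbon would hold the read-out of compound 1 (68.7%).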